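This account rests on a few compounds, and the source may have more. Where it says the series, first, only, none or still open, it means among the compounds named here.

Of the compounds shown here, two built on one shared core have been measured in a functional assay on HeLa cells (Homo sapiens) for cytotoxicity, read by XTT assay, with a stated time of 24 h; a higher number here means a weaker inhibitor, a lower number a stronger inhibitor. Compound 1 `Cc1cc(O)c2c(c1F)C(=O)C=CC2=O` gives 10200 nM. Compound 2 `CC(=O)Oc1c(C)cc(Cl)c2c1C(=O)C=CC2=O` gives 21800 nM, the higher of the two numbers, and its gap to compound 1 lies beyond the usual scatter. Compound 3 `Cc1cc(Cl)c2c(c1O)C(=O)C=CC2=O` has not been measured yet; it differs from compound 2 by hydrogen in place of acetyl on an oxygen on an aromatic ring. Going by the values given here, no measured pair shows this exact change. Compound 1 also carries a hydroxy and gives 10200 nM, so a modest fall in the number is expected a 1.8-fold lower number from compound 2 to compound 3 (0.26 log units; within the scatter). Compound 3 is estimated at 12000 nM, within a range from 5000 nM to 30000 nM.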

Compound 3, half-maximal inhibitory concentration: 10100 nM
Compound 3: the middle estimate sits 1.2-fold (0.07 log units) above what was measured, and the stated range covers the measured number.
By their numbers in this assay, from the lowest: compounds 3 and 1 (each within the scatter of the next); then compound 2.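

Going from acetoxy to hydroxy on this oxygen on an aromatic ring gives a 2.2-fold lower number from compound 2 to compound 3 (0.33 log units; beyond the scatter) in this assay and is a modest step. The acetyl is therefore not needed for the cytotoxicity seen here, and the free hydroxy gives the lower number. Nothing measured here accounts for this step.

From the compounds shown here alone, whether a methyl ether or a longer ester such as butyryl on this oxygen would move the number further stays open. So does whether an amine in place of the hydroxy would keep it.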